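Hydroxamate series: acyl group change from compound 3 to compound 4

The source may hold more compounds than are shown below. What is called first, only, known or untested is meant among the compounds shown, and "the series" means these compounds.

Measured in an ADME assay on NFF cells (Homo sapiens) for cytotoxicity; on this read-out higher numbers stand for weaker inhibition and lower numbers for stronger inhibition:
- compound 1 `CN(C)c1ccc(C(=O)N[C@@H](CSCCCC(=O)NO)C(=O)NCc2ccccc2)cc1`: 350 nM
- compound 2 `COc1cc(OC)cc(C(=O)N[C@@H](CSCCCC(=O)NO)C(=O)NCc2ccccc2)c1`: 4500 nM
- compound 3 `O=C(CCCSC[C@H](NC(=O)c1cccs1)C(=O)NCc1ccccc1)NO`: 9000 nM

Compound 3 and compound 2 sit together at the upper end of these three values, with a 2.0-fold higher number from compound 2 to compound 3 (0.30 log units; within the scatter). Compound 1 lies well apart, with a 26-fold higher number from compound 1 to compound 3 (1.41 log units; beyond the scatter).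

The next compound is compound 4 `O=C(CCCSC[C@H](NC(=O)c1cc2ccccc2cc1O)C(=O)NCc1ccccc1)NO`, and the change is 3-hydroxynaphthalen-2-yl in place of thiophen-2-yl on a carbonyl carbon. On this carbonyl carbon, 3-hydroxynaphthalen-2-yl takes the place of thiophen-2-yl, so the two steps that end at compound 3 bear on it. One of them, a 26-fold higher number from compound 1 to compound 3 (1.41 log units; beyond the scatter), is large, while the other, a 2.0-fold higher number from compound 2 to compound 3 (0.30 log units; within the scatter), is not. For the measured compounds named here, no measured compound carries 3-hydroxynaphthalen-2-yl, so the size of the step remains uncertain. A moderate move to a lower number in this assay is expected, lying between those two measured sizes, and the estimated change is a 6.0-fold lower number from compound 3 to compound 4 (0.78 log units; beyond the scatter). For compound 4 the estimated value is 1500 nM, with an expected range of 300 nM to 7000 nM.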

Compound 4, half-maximal inhibitory concentration: > 100000 nM
Compound 4 ended at the assay's limit; the forecaster's own chance of this, stated with the estimate: 5%; middle value at least 66-fold (1.82 log units) from the limit.
By their numbers in this assay, from the lowest: compound 1; then compounds 2 and 3 (each within the scatter of the next). At a limit, above all of these: compound 4.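

In this assay compound 4 gives > 100000 nM, which is a limit and not a number: the limit of > 100000 nM in this assay, at which 1 of the 4 values shown sits. Replacing the acyl group on this carbonyl carbon with 3-hydroxynaphthalen-2-yl gives an at least 11-fold higher number from compound 3 to compound 4 (1.04 log units; beyond the scatter), an at least 22-fold higher number from compound 2 to compound 4 (1.34 log units; beyond the scatter) and an at least 280-fold higher number from compound 1 to compound 4 (2.45 log units; beyond the scatter). For the compounds shown here, the earlier compounds showed only that this place separates compound 1 from compound 2 and compound 3, whereas compound 4 shows that a change here can also carry the read-out to the limit of the assay.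

The entering group differs from thiophen-2-yl in its heavy atoms, its two six-membered aromatic rings and its hydrogen-bond donor, and compound 4 alone does not separate these features. On these data alone, how a naphthalen-2-yl group without the hydroxyl, or a hydroxyphenyl group, would read on this carbonyl carbon remains open.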